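Swapping the sulfonamide substituent of compound 1: an expectation

The source may report more compounds than this note shows. Statements on the series, on what has been measured and on what is new or still open speak of the compounds shown alone.

This account concerns a set of hydroxamic acids sharing a tetrafluorophenylsulfonamide core and follows one structural change. Going by the values given here, compound 1 `O=C(NO)c1ccc(CN(C2CC2)S(=O)(=O)c2cc(F)c(F)c(F)c2F)cc1` gives 400 nM in a functional assay on MV4-11 cells (Homo sapiens) for inhibition, with a stated time of 72 h (a higher number here means a weaker inhibitor, a lower number a stronger inhibitor), the lowest of the two numbers recorded; the only other measured compound, compound 2 `CC(C)N(Cc1ccc(C(=O)NO)cn1)S(=O)(=O)c1cc(F)c(F)c(F)c1F`, gives 1000 nM in this assay, a number that lies beyond the scatter of compound 1. Among the compounds with values here, compound 2 differs from compound 1 in more than one place, so no single-change step links them. The unmeasured compound 3 `COCCN(Cc1ccc(C(=O)NO)cc1)S(=O)(=O)c1cc(F)c(F)c(F)c1F` arises from compound 1 by one change: 2-methoxyethyl in place of cyclopropyl on a sulfonamide nitrogen. Within the data shown here, no measured pair shows the effect of such a change, so the expectation rests on compound 1 alone. The step from compound 1 to compound 3 in this assay is expected to be small, a 1.5-fold higher number from compound 1 to compound 3 (0.18 log units; within the scatter), possibly within the scatter. Compound 3 is therefore estimated at 600 nM in this assay, with a range from 250 nM to 1500 nM.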

Compound 3, half-maximal inhibitory concentration: 660 nM
Beside the measured number, compound 3's estimate is 1.1-fold (0.04 log units) below it; measured number inside the range.
By their numbers in this assay, from the lowest: compounds 1, 3 and 2 (each within the scatter of the next, the first and the last beyond it).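

Going by these compounds alone, compound 3 supplies the first single-change step at this sulfonamide nitrogen: in this assay the change to 2-methoxyethyl gives a 1.7-fold higher number from compound 1 to compound 3 (0.22 log units; within the scatter) and so cannot be told apart from repeat measurement. The position therefore holds an open chain with no ring and a hydrogen-bond acceptor as well as it holds cyclopropyl, at least for this one pair. Nothing at hand bears on why the two numbers stand so close.

On these data alone, whether that holds for other groups on this nitrogen, such as an amine, a carboxylic acid or a longer chain, remains open. Compound 2 differs from compound 1 in more than one place, so how much of the gap between their numbers belongs to this nitrogen's substituent also stays unresolved.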